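A few compounds are considered here, and "the series" means these few. Any claim that something is new, unique, unknown or untested is made for them only; others in the source may bear on it.

Measured compounds:
compound 1, `CCCCCCCCCCCCCCC[C@@H](O)[C@@H](N)[C@@H](C)O`: 17000 nM
compound 2, `CCCCCCCCC[C@@H](O)[C@H](C)N`: 9500 nM
compound 3, `CCCCCCCCC[C@@H](O)[C@@H](N)[C@@H](C)CC`: 13000 nM

All three were read in a functional assay on SW1573 cells (Homo sapiens) for antiproliferative activity, read by sulforhodamine B assay, with a stated time of 48 h; on this read-out lower numbers stand for stronger inhibition of growth and higher numbers for weaker inhibition of growth. Compound 3 stands second highest of the three numbers; its nearest neighbour is compound 1 and compound 2 lies furthest from it, yet neither gap reaches beyond the scatter, so the three compounds cannot be ordered on these data.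

Compound 4, `CCCCCCCCC[C@@H](O)[C@@H](N)[C@@H](C)O`, has not yet been measured in this assay. It differs from compound 3 by hydroxy in place of ethyl on a saturated chain carbon bound to two saturated chain carbons. Going by the values given here, only one measured step touches the same position: a 1.4-fold higher number from compound 2 to compound 3 (0.14 log units; within the scatter), and that stayed within the scatter. Among the compounds with values here, no measured pair shows an ethyl exchanged for a hydroxy, but compound 1 carries the 1-hydroxyethyl group on a longer chain and in this assay compound 1 gives 17000 nM, close to the number for compound 3. With nothing to argue for a shift in either direction, no step beyond the scatter is expected in this assay; the expected step is a 1.2-fold higher number from compound 3 to compound 4 (0.06 log units; within the scatter). For compound 4 the estimated value in this assay is 15000 nM, with an expected range from 7000 nM to 35000 nM.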

Compound 4, concentration for 50% growth inhibition: 17000 nM
Compound 4: the middle estimate sits 1.1-fold (0.05 log units) below what was measured, and the stated range covers the measured number.
By their numbers in this assay, from the lowest: compounds 2, 3, 1 and 4 (each within the scatter of the next).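

In this assay the direct exchange of ethyl for hydroxy on a saturated chain carbon bound to two saturated chain carbons gives a 1.3-fold higher number from compound 3 to compound 4 (0.12 log units; within the scatter) and so stays within the scatter, which means that adding a hydrogen-bond donor and acceptor here, and dropping from two heavy atoms to one, leaves the read-out unresolved from that of the ethyl compound. The wider exchange of 1-hydroxyethyl in place of methyl on a saturated chain carbon bound to an amine nitrogen and a saturated chain carbon gives a 1.8-fold higher number from compound 2 to compound 4 (0.25 log units; within the scatter) and is also within the scatter, so this position has now tolerated all three side groups without a resolved shift. With 1-hydroxyethyl held fixed, the pair that isolates chain length gives no change at the digits printed from compound 1 to compound 4 (within the scatter), so removing hexyl from the far end of the chain shows no effect on this read-out.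

As far as these compounds go, whether a phenyl group, a carboxylic acid or an amide at this position would move the number beyond the scatter stays open, as does the effect of inverting the carbon that carries the hydroxy group. Nothing on hand offers an explanation for these numbers.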